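The compounds below may be only part of what the source reports. "The series", "measured", "known", "first", "only" and "open" are said of these compounds alone.

Measured so far in an ADME assay on the whole organism (Mus musculus, strain CD-1) for pharmacokinetics; a lower number here means slower removal, a higher number faster removal of the compound:

- compound 1 `CCOc1cc([C@](O)(CCN(C)C)[C@@H](c2cc3cc(Br)ccc3nc2OC)c2ccnc(OC)c2OC)cc(OC)n1` gives 9.5 mL/min/kg
- compound 2 `COc1cc([C@](O)(CCN(C)C)[C@@H](c2cc3cc(Br)ccc3nc2OC)c2ccnc(OC)c2OC)cc(OC(F)F)n1` gives 8.7 mL/min/kg
- compound 3 `COc1cccc([C@H](c2cc3cc(Br)ccc3nc2OC)[C@@](O)(CCN(C)C)c2cc(SC)nc(SC)c2)c1F` gives 13 mL/min/kg

Compound 3 at 13 mL/min/kg lies within the scatter of both compound 1 and compound 2, so the three values cannot be ranked.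

Compound 4 `COc1nc2ccc(Br)cc2cc1[C@@H](c1ccnc(OC)c1OC)[C@@](O)(CCN(C)C)c1cc(SC)nc(SC)c1` is the next case. It differs from compound 3 in one group: 2,3-dimethoxypyridin-4-yl in place of 2-fluoro-3-methoxyphenyl on a saturated chain carbon bound to an aromatic carbon and a saturated chain carbon.

For the measured compounds named here, no measured step covers this exchange. Going by the values given here, the only single-place step, a 1.1-fold lower number from compound 1 to compound 2 (0.04 log units; within the scatter), is at another place in the molecule and stays within the scatter, so it gives only indirect support. Compound 1 and compound 2 already carry the 2,3-dimethoxypyridin-4-yl group, and they differ from compound 3 in other places too. With that group, compound 1 gives 9.5 mL/min/kg and compound 2 gives 8.7 mL/min/kg, which offers no sign that the group moves this assay far from the values seen so far.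

The expected step is a 1.2-fold lower number from compound 3 to compound 4 (0.07 log units; within the scatter), which is none beyond the scatter, and its direction is only tentative. For compound 4 the estimated value is 11 mL/min/kg, with an expected range from 6 mL/min/kg to 19 mL/min/kg.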

Compound 4, clearance: 18 mL/min/kg
Beside the measured number, compound 4's estimate is 1.6-fold (0.21 log units) below it; the measured number falls inside the stated range.
By their numbers in this assay, from the lowest: compounds 2, 1, 3 and 4 (each within the scatter of the next, the first and the last beyond it).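

In this assay, for the compounds shown here, the first direct reading of this exchange, on a saturated chain carbon bound to an aromatic carbon and a saturated chain carbon, is (a 1.4-fold higher number from compound 3 to compound 4 (0.14 log units; within the scatter)): 2,3-dimethoxypyridin-4-yl in place of 2-fluoro-3-methoxyphenyl does not separate the two compounds. With 2,3-dimethoxypyridin-4-yl shared, the sulfur-bearing aromatic group on a saturated chain carbon bound to an oxygen on a saturated carbon and two saturated chain carbons gives the first modest separation in the series when it replaces the group carrying difluoromethyl (a 2.1-fold higher number from compound 2 to compound 4 (0.32 log units; beyond the scatter)), whereas the comparison with the group carrying ethyl stays within the scatter (a 1.9-fold higher number from compound 1 to compound 4 (0.28 log units; within the scatter)). No measurement available here accounts for either step.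

Open, from the compounds shown here alone, is how this assay would respond to an amine or a carboxylic acid in place of 2,3-dimethoxypyridin-4-yl at the saturated chain carbon bound to an aromatic carbon and a saturated chain carbon. Also open, going by these compounds, is whether a longer chain on the oxygen of the group carrying ethyl would widen or close the modest separation seen with the sulfur-bearing group.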